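This account rests on a few compounds, and the source may have more. Where it says the series, first, only, none or still open, it means among the compounds named here.

Compound 1 `O=C(CCCOC(=O)c1ccc2c(c1)no[n+]2[O-])NO` gives 17000 nM
Compound 2 `O=C(CCCCOC(=O)c1ccc2c(c1)no[n+]2[O-])NO` gives 15900 nM

In a functional assay on HeLa cells (Homo sapiens) for inhibition, read by MTT assay, with a stated time of 48 h (on this read-out lower numbers stand for stronger inhibition and higher numbers for weaker inhibition), compound 2 gives 15900 nM and sits within the usual scatter of compound 1, so the two numbers cannot be told apart. Compound 3 `O=C(CCCCCOC(=O)c1ccc2c(c1)no[n+]2[O-])NO` has not been measured yet. It differs from compound 2 by one change: (hydroxycarbamoyl)methyl in place of hydroxycarbamoyl on a saturated chain carbon, four bonds along the chain from an oxygen next to a carbonyl group which in words is (hydroxycarbamoyl)methyl in place of hydroxycarbamoyl, four bonds along the chain from an oxygen next to a carbonyl group. Among the measured compounds shown here, the only measured step of this kind is a 1.1-fold lower number from compound 1 to compound 2 (0.03 log units; within the scatter) and it made the same swap three bonds along the chain. With that single small step as a guide, no shift beyond the scatter is expected in this assay in either direction. The expected outcome is a 1.1-fold lower number from compound 2 to compound 3 (0.06 log units; within the scatter) by this estimate. For compound 3 the estimated value is 14000 nM with 6000 nM to 30000 nM as the expected range.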

Compound 3, half-maximal inhibitory concentration: 17300 nM
Compound 3: the middle estimate sits 1.2-fold (0.09 log units) below what was measured; measured number inside the range.
By their numbers in this assay, from the lowest: compounds 2, 1 and 3 (each within the scatter of the next).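

In this assay, lengthening the chain once more, with (hydroxycarbamoyl)methyl in place of hydroxycarbamoyl four bonds along the chain from an oxygen next to a carbonyl group, gives a 1.1-fold higher number from compound 2 to compound 3 (0.04 log units; within the scatter) and so shows no readable effect at this further position. The two changes taken together, with 2-(hydroxycarbamoyl)ethyl in place of hydroxycarbamoyl, give a 1.0-fold higher number from compound 1 to compound 3 (0.01 log units; within the scatter) as well, so the small first step does not build into a trend, and these three chain lengths cannot be told apart in this assay at all. Nothing at hand speaks to why the numbers stay so close.

Still open, as far as these compounds go, is whether a longer chain would finally move the number away from this level. From the compounds shown here alone, it is equally open whether a carboxylic acid or an amine at the chain end, in place of hydroxycarbamoyl, would do so.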